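From Cyclohexyl to Iodo: A Growth Inhibition Step

The compounds below may be only part of what the source reports. "The series", "measured", "known", "first", "only" and "open" are said of these compounds alone.

Measured in a functional assay on HT-29 cells (Homo sapiens) for inhibition, read by sulforhodamine B assay, with a stated time of 48 h; a higher number here means a weaker inhibitor of growth, a lower number a stronger inhibitor of growth:
Compound 1 `c1cc(NC2=NCCO2)cc(OC2CCCC2)c1`: 52200 nM
Compound 2 `O=C(CCl)NC(=O)Nc1ccc(C2CCCCC2)cc1`: 2300 nM

Of these two compounds, compound 2 stands lowest at 2300 nM and is thus the stronger inhibitor of growth, a gap to compound 1 that lies beyond the usual scatter. The next compound to be tested, compound 3 `O=C(CCl)NC(=O)Nc1ccc(I)cc1`, is compound 2 with iodo in place of cyclohexyl on an aromatic carbon, para to a group of 8 heavy atoms: iodo in place of cyclohexyl on an aromatic carbon. Among the compounds with values here, no measured pair shows what this exchange does, so the expectation is tentative and starts from compound 2 alone. A modest move toward a higher number in this assay is expected, with no large loss foreseen. The expected change is a 2.2-fold higher number from compound 2 to compound 3 (0.34 log units; beyond the scatter), which may prove only slightly beyond the scatter. Compound 3 is estimated at 5000 nM, with a range of 1800 nM to 14000 nM.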

Compound 3, concentration for 50% growth inhibition: 6900 nM
The estimate for compound 3 lay 1.4-fold (0.14 log units) below the measured number; the measured number falls inside the stated range.
By their numbers in this assay, from the lowest: compound 2; then compound 3; then compound 1.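

In this assay, within the data shown here, the exchange of cyclohexyl for iodo on this aromatic carbon gives a 3.0-fold higher number from compound 2 to compound 3 (0.48 log units; beyond the scatter), the first measured step at this position. It shows that the number responds to the group placed here, although the step is modest, and that the six-membered non-aromatic ring of carbon is not required for a measurable value, as compound 3 gives 6900 nM. No evidence at hand accounts for the size or direction of this step.

The compounds shown leave open how other groups at this place, such as bromo, methoxy, an amine or a carboxylic acid, would compare with iodo and cyclohexyl. With a single step at this position, no trend across groups can yet be drawn.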